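This account rests on a few compounds, and the source may have more. Where it says the series, first, only, none or still open, it means among the compounds named here.

Compound 1 `Cn1c(=O)c(S(=O)(=O)c2ccc(Cl)cc2Cl)cc2cnc(Nc3ccc4[nH]ccc4c3)nc21` and compound 2 `COC(=O)Cn1ccc2cc(Nc3ncc4cc(S(=O)(=O)c5ccc(F)cc5F)c(=O)n(C)c4n3)ccc21` share one core. In a functional assay on DU-145 cells (Homo sapiens) for inhibition, read by trypan blue exclusion, with a stated time of 72 h (on this read-out lower numbers stand for stronger inhibition and higher numbers for weaker inhibition), compound 1 gives 1000 nM, the lower of the two numbers, while compound 2 gives 5000 nM, a gap beyond the usual scatter. Compound 3 `Cn1c(=O)c(S(=O)(=O)Nc2ccc(F)cc2F)cc2cnc(Nc3ccc4[nH]ccc4c3)nc21` is not yet measured and differs from compound 1 in one place: (2,4-difluorophenyl)amino in place of 2,4-dichlorophenyl on a sulfonyl sulfur. Among the compounds with values here, no measured pair tests this change, so its direction rests on no data. A modest weakening is expected for compound 3, a 2.0-fold higher number from compound 1 to compound 3 (0.30 log units; within the scatter) in this assay. Compound 3 is estimated at 2000 nM, with a range from 500 nM to 8000 nM.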

Compound 3, half-maximal inhibitory concentration: 5000 nM
The estimate for compound 3 lay 2.5-fold (0.40 log units) below the measured number; the range from low to high includes it.
By their numbers in this assay, from the lowest: compound 1; then compounds 2 and 3 (each within the scatter of the next).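

Within the data shown here, on the sulfonyl sulfur, (2,4-difluorophenyl)amino in place of 2,4-dichlorophenyl gives a 5.0-fold higher number from compound 1 to compound 3 (0.70 log units; beyond the scatter) in this assay and is the first direct reading of a change at this place. Among these compounds, the single step alters both the amino link and the halogens on the ring, so it cannot separate the two. Nothing available bears on the origin of this step. Open, as far as these compounds go, is whether (2,4-dichlorophenyl)amino on the sulfonyl sulfur would read closer to compound 1 or compound 3, and how a saturated amine such as morpholine would read at this place.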